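Extending the chain beneath a phthalimide end group

A few compounds are considered here, and "the series" means these few. Any claim that something is new, unique, unknown or untested is made for them only; others in the source may bear on it.

Compound 1, `COc1cc(N)c(Cl)cc1C(=O)NC1CCN(CCCCCCCCO)CC1`, gives > 100% in a functional assay on HEK293 cells for activation of 5-hydroxytryptamine receptor 4 (Homo sapiens), read by cAMP accumulation (on this read-out higher numbers stand for larger maximal responses and lower numbers for smaller maximal responses), which is a limit of the assay and not a number.
Compound 2, `COc1cc(N)c(Cl)cc1C(=O)NC1CCN(CCCCCN2C(=O)c3ccccc3C2=O)CC1`, gives > 100% in this assay, again a limit of the assay.

Compound 1 therefore stands only at a limit on the numbers shown, and the one further value, that of compound 2, is a limit as well. Among the compounds with values here, the single measured step, a step that the two limits leave unreadable from compound 1 to compound 2, cannot be read for size because of the limit of > 100% in this assay, at which 2 of the 2 values shown sit. Compound 3, `COc1cc(N)c(Cl)cc1C(=O)NC1CCN(CCCCCCCCN2C(=O)c3ccccc3C2=O)CC1`, is not yet measured. It differs from compound 1 in that (a group of 11 heavy atoms (8 carbon, 1 nitrogen, 2 oxygen; one five-membered non-aromatic ring with 1 hetero atom, one six-membered aromatic ring of carbon only) in place of one oxygen atom, on a saturated chain carbon, eight bonds along the chain from an amine nitrogen in a ring). Within the data shown here, the only measured step that bears on this change is the one from compound 1 to compound 2, where the same group enters on a shorter chain, and it gives no readable size. With both measured values sitting at the limit, the expectation for compound 3 is that it reaches the limit too, so that no step beyond the scatter, a step that the limit leaves unreadable from compound 1 to compound 3, is expected in this assay. Compound 3 is therefore estimated at 105%, within 88% to 125%.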

Compound 3, intrinsic activity: the largest response reached, in percent of the reference agonist's: 89%
Compound 3: the middle estimate sits 16 percentage points above what was measured; low and high end bracket the measured number.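

In this assay, replacing the hydroxy group with the group of 11 heavy atoms, on a saturated chain carbon, eight bonds along the chain from an amine nitrogen in a ring, gives a number at least 11 percentage points lower from compound 1 to compound 3 (beyond the scatter). Compound 3 gives 89%, which makes it the only compound shown whose maximal response is a number and not a limit of the assay. The earlier step, which brought the same group in on a shorter chain, cannot be read, so this is the first sign that the change can lower the response, and the reason the earlier step gave no such sign is this: the limit of > 100% in this assay, at which 2 of the 3 values shown sit.

How much of the new step belongs to the entering group and how much to the length of the chain stays unsettled, as compound 2 offers only a limit and no number to set against compound 3. Also open, going by these compounds, is how the response would move with a longer chain under the same end group, or with an amine or a carboxylic acid at the chain end in its place.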